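The source may hold more compounds than are shown below. What is called first, only, known or untested is meant among the compounds shown, and "the series" means these compounds.

Working notes on the alkoxy series built on the shared core of compound 1 `CCCCCCOc1c(-c2cc(OC)c(OC)c(OC)c2)oc2ccccc2c1=O`. In a functional assay on PC-3 cells (Homo sapiens) for antiproliferative activity, read by WST assay, with a stated time of 3 days (on this read-out higher numbers stand for weaker inhibition and lower numbers for stronger inhibition), compound 1 gives 29200 nM, the second highest of the three numbers. Compound 2 `COc1cc(-c2oc3ccccc3c(=O)c2OC(C)C)cc(OC)c1OC` gives 21200 nM in this assay, and compound 3 `CCCC(C)Oc1c(-c2cc(OC)c(OC)c(OC)c2)oc2ccccc2c1=O` gives 49300 nM. The steps among these three stay small: a 1.4-fold lower number from compound 1 to compound 2 (0.14 log units; within the scatter), a 1.7-fold higher number from compound 1 to compound 3 (0.23 log units; within the scatter), and a 2.3-fold higher number from compound 2 to compound 3 (0.37 log units; beyond the scatter), the last being the only one beyond the scatter, and then only modestly. Varying the alkyl group on the aromatic oxygen therefore moves this assay little.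

Compound 4 `CCCCN(CCCC)CCCCCOc1c(-c2cc(OC)c(OC)c(OC)c2)oc2ccccc2c1=O` is not yet measured. Its difference from compound 1: dibutylamino in place of methyl on a saturated chain carbon, five bonds along the chain from an oxygen on an aromatic ring. Among the compounds with values here, none of the measured steps covers this change; the alkyl steps above only show that changes on the chain attached to the aromatic oxygen have so far given small movements, so the expectation for compound 4 rests on weak footing and the range is set wide. The expected step is a 2.4-fold lower number from compound 1 to compound 4 (0.39 log units; beyond the scatter), with no confident direction. Compound 4 is estimated at 12000 nM in this assay, within a range from 3000 nM to 50000 nM.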

Compound 4, half-maximal inhibitory concentration: 6800 nM
Compound 4: the middle estimate sits 1.8-fold (0.25 log units) above what was measured, within the range that was stated.
By their numbers in this assay, from the lowest: compound 4; then compounds 2, 1 and 3 (each within the scatter of the next, the first and the last beyond it).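

In this assay, dibutylamino in place of methyl, five bonds along the chain from an oxygen on an aromatic ring, gives a 4.3-fold lower number from compound 1 to compound 4 (0.63 log units; beyond the scatter), a modest movement towards stronger inhibition. Within the data shown here, the alkyl changes gave a 1.4-fold lower number from compound 1 to compound 2 (0.14 log units; within the scatter) and a 1.7-fold higher number from compound 1 to compound 3 (0.23 log units; within the scatter), so compound 4 is the first change from compound 1 to lie beyond the scatter, which shows that the far end of this chain can shift the number and that a nitrogen-bearing group with nine heavy atoms is accepted there without loss. Nothing measured in this series accounts for the size or direction of this step.

Compound 4 changes the chain length and adds the amine at once, so the compounds shown cannot separate the two, and a plain longer chain without nitrogen would be the direct comparison. Also open, from the compounds shown here alone, is how far the step depends on the amine itself, which a smaller dimethylamino group, a ring amine such as piperidine, or a shorter or longer chain carrying dibutylamino would test.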